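The source may hold more compounds than are shown below. What is called first, only, known or untested is meant among the compounds shown, and "the series" means these compounds.

Measured compounds in a functional assay on HepG2 cells (Homo sapiens) for antiproliferative activity, read by CCK-8 assay, with a stated time of 72 h; on this read-out higher numbers stand for weaker inhibition and lower numbers for stronger inhibition:

compound 1 `O=C(Nc1cccc(-c2oc3cc(-c4ccc(F)cc4)ccc3c(=O)c2O)c1)c1ccc(F)cc1` — 9280 nM
compound 2 `COc1ccccc1C(=O)Nc1cccc(-c2oc3cc(-c4ccc(F)cc4)ccc3c(=O)c2O)c1` — 14500 nM
compound 3 `O=C(Nc1cccc(-c2oc3cc(-c4ccc(F)cc4)ccc3c(=O)c2O)c1)c1cccc(F)c1` — 15500 nM

Compound 3 has the highest number of the three, but its gaps to compound 2 and to compound 1 are both within the scatter, so no order among them can be read from the numbers. The three differ only in the aryl group on the carbonyl carbon, and each such exchange left this assay essentially flat: a 1.6-fold higher number from compound 1 to compound 2 (0.19 log units; within the scatter), a 1.7-fold higher number from compound 1 to compound 3 (0.22 log units; within the scatter), a 1.1-fold higher number from compound 2 to compound 3 (0.03 log units; within the scatter).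

Compound 4 `COc1cc(OC)cc(C(=O)Nc2cccc(-c3oc4cc(-c5ccc(F)cc5)ccc4c(=O)c3O)c2)c1` is the next member of this kind. The change from compound 3 is 3,5-dimethoxyphenyl in place of 3-fluorophenyl on a carbonyl carbon. It is the same sort of exchange as the three steps already seen, and all of those stayed inside the scatter, so the same is expected here: a step in this assay, a 1.0-fold higher number from compound 3 to compound 4 (0.01 log units; within the scatter), that is not expected to exceed the scatter, with no clear direction. For compound 4 the estimate is therefore 16000 nM, with a range from 7000 nM to 40000 nM.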

Compound 4, half-maximal inhibitory concentration: 23500 nM
Beside the measured number, compound 4's estimate is 1.5-fold (0.17 log units) below it; low and high end bracket the measured number.
By their numbers in this assay, from the lowest: compounds 1, 2, 3 and 4 (each within the scatter of the next, the first and the last beyond it).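

In this assay, within the data shown here, 3,5-dimethoxyphenyl on the carbonyl carbon gives the only step in this set to pass the scatter, a 2.5-fold higher number from compound 1 to compound 4 (0.40 log units; beyond the scatter), while a 1.5-fold higher number from compound 3 to compound 4 (0.18 log units; within the scatter) and a 1.6-fold higher number from compound 2 to compound 4 (0.21 log units; within the scatter) stay inside it. The position therefore accepts this larger aryl group with only a small shift, and the separation holds for the compound 1 and compound 4 pair alone; compound 2, which also carries a methoxy group, does not separate from either. No measurement at hand accounts for this step.

Going by these compounds, whether the separation follows from the two methoxy groups or from the loss of fluorine stays open. On these data alone, only substituted phenyl groups sit on this carbonyl carbon here, so how a morpholine amine, a carboxylic acid or a longer alkyl chain there would read also stays open.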